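Replacing pyridin-3-yl with 2-chlorophenyl in compound 1

The source may hold more compounds than are shown below. What is called first, only, known or untested is meant among the compounds shown, and "the series" means these compounds.

Compound 1 `CCCSc1nc(N/N=C/c2cccnc2)c2nnn(Cc3ccccc3)c2n1`: > 64000 nM
Compound 2 `C#CCSc1nc(N/N=C/c2ccc(N(C)C)cc2)c2nnn(Cc3ccccc3)c2n1`: 31300 nM

In a functional assay on ECa-109 cells (Homo sapiens) for antiproliferative activity, read by MTT assay, with a stated time of 72 h (a higher number here means a weaker inhibitor, a lower number a stronger inhibitor), compound 1 stands at a limit of the assay and not at a number, > 64000 nM. Compound 2 gives a true number, 31300 nM, but no single-place change links the two measured compounds. Compound 3 `CCCSc1nc(N/N=C/c2ccccc2Cl)c2nnn(Cc3ccccc3)c2n1` has 2-chlorophenyl in place of pyridin-3-yl on a carbon with a double bond to nitrogen. Going by the values given here, with no measured step as a guide, only a modest gain in strength is expected in this assay, and it may stay small. The expected change is an at least 2.2-fold lower number from compound 1 to compound 3 (0.35 log units; beyond the scatter). Compound 3 is estimated at 28000 nM, with an expected range from 8000 nM to 64000 nM.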

Compound 3, half-maximal inhibitory concentration: 6180 nM
The estimate for compound 3 lay 4.5-fold (0.66 log units) above the measured number; the whole stated range lies above it.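

In this assay, the carbon with a double bond to nitrogen proves to be a place where one change matters: 2-chlorophenyl in place of pyridin-3-yl gives an at least 10-fold lower number from compound 1 to compound 3 (1.01 log units; beyond the scatter). Compound 1 gives only a limit, > 64000 nM, and not a number. The step can therefore be read only as a minimum size: the limit of > 64000 nM in this assay, at which 1 of the 3 values shown sits.

This single pair cannot separate the role of the chlorine from that of the all-carbon ring. A plain phenyl group at the same place would tell these two apart.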